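From 4-iodophenyl to 2-chlorophenyl on a shared core

This account rests on a few compounds, and the source may have more. Where it says the series, first, only, none or still open, it means among the compounds named here.

Of the compounds shown here, three sharing one core have been measured in a functional assay on FM3A cells (Mus musculus) for antiproliferative activity; a higher number here means a weaker inhibitor, a lower number a stronger inhibitor. Compound 1 `COc1cc(C(=O)c2sc(-c3ccc(-c4ccccc4)cc3)cc2N)cc(OC)c1OC` gives only a limit of the assay, > 10000 nM, and not a number. Compound 2 `COc1cc(C(=O)c2sc(-c3ccc(Cl)cc3)cc2N)cc(OC)c1OC` gives 90 nM and compound 3 `COc1cc(C(=O)c2sc(-c3ccc(I)cc3)cc2N)cc(OC)c1OC` gives 420 nM. Compound 3 therefore holds the higher of the two true numbers, while compound 1 lies at the limit.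

The next compound is compound 4 `COc1cc(C(=O)c2sc(-c3ccccc3Cl)cc2N)cc(OC)c1OC`, in which 2-chlorophenyl stands in place of 4-iodophenyl on an aromatic carbon: 2-chlorophenyl in place of 4-iodophenyl on an aromatic carbon. Two measured steps replace the phenyl of compound 1, an at least 110-fold lower number from compound 1 to compound 2 (2.04 log units; beyond the scatter) and an at least 23-fold lower number from compound 1 to compound 3 (1.37 log units; beyond the scatter). Both are large, but neither resembles this change. Closer is the halogen exchange, a 4.7-fold higher number from compound 2 to compound 3 (0.67 log units; beyond the scatter), which is modest and suggests that chloro could lower the number. However, no measured step moves a group around the phenyl ring, and that part of the change remains untested. A modest step towards a higher number therefore seems the likelier outcome, with wide uncertainty in either direction.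

The expected change is a 2.4-fold higher number from compound 3 to compound 4 (0.38 log units; beyond the scatter). For compound 4 the estimated value in this assay is 1000 nM, with an expected range of 150 nM to 6000 nM.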

Compound 4, half-maximal inhibitory concentration: 34 nM
The estimate for compound 4 lay 29-fold (1.47 log units) above the measured number; the whole stated range lies above it.
By their numbers in this assay, from the lowest: compound 4; then compound 2; then compound 3. At a limit, above all of these: compound 1.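

Among these compounds, with 2-chlorophenyl in place of 4-chlorophenyl, this assay shows a 2.6-fold lower number from compound 2 to compound 4 (0.42 log units; beyond the scatter) and this is the first measured evidence that moving the chloro group on the phenyl ring matters at this position, on the aromatic carbon next to the ring sulfur. The full change gives a 12-fold lower number from compound 3 to compound 4 (1.09 log units; beyond the scatter) and, read with the halogen exchange, a 4.7-fold higher number from compound 2 to compound 3 (0.67 log units; beyond the scatter) and the chloro group's new place on the ring, both parts of the change point towards a lower number. No measurement shown here accounts for this gain at the position, and the only supporting line concerns a different compound.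

From the compounds shown here alone, whether the gain belongs to chloro alone or would also appear with 2-fluorophenyl, 2-methylphenyl or 2-methoxyphenyl stays open, as does the effect of 3-chlorophenyl. Compound 1 stays a limit at > 10000 nM and not a number, so what a phenyl group would do at the place that chloro occupies in 2-chlorophenyl is also unresolved.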